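The compounds below may be only part of what the source reports. "The series", "measured", "known", "first", "only" and "open" are said of these compounds alone.

Among the measured compounds shown here, in a functional assay on MV4-11 cells (Homo sapiens) for antiproliferative activity, read by CCK-8 assay, with a stated time of 72 h (a higher number here means a weaker inhibitor, a lower number a stronger inhibitor), compound 3 (`Cn1cc(-c2ccccc2Oc2ccccc2)c2cc(C(=O)NCCCCC(=O)Nc3ccccc3N)[nH]c2c1=O`) gives 240 nM, the lowest number of the series so far. Compound 2 (`Cn1cc(-c2ccccc2Oc2ccccc2)c2cc(C(=O)NCc3ccc(C(=O)NO)cc3)[nH]c2c1=O`) gives 570 nM and compound 1 (`Cn1cc(-c2ccccc2Oc2ccccc2)c2cc(C(=O)NCCCCCC(=O)NO)[nH]c2c1=O`) gives 610 nM. Both of these numbers stand beyond the scatter from that of compound 3. Compound 4 (`Cn1cc(-c2ccccc2Oc2ccccc2)c2cc(C(=O)NCCCCC(=O)NO)[nH]c2c1=O`) differs from compound 3 by hydroxy in place of 2-aminophenyl on an amide-type nitrogen. For the measured compounds named here, the nearest precedent is a 2.5-fold lower number from compound 1 to compound 3 (0.41 log units; beyond the scatter), which is not an exact reverse, as (hydroxycarbamoyl)methyl leaves there. The other step, a 1.1-fold lower number from compound 1 to compound 2 (0.03 log units; within the scatter), shows no separation between two hydroxycarbamoyl compounds. A modest rise in this assay is therefore expected, of similar or slightly smaller size, and the expected step is a 1.9-fold higher number from compound 3 to compound 4 (0.27 log units; within the scatter). Compound 4 is estimated at 450 nM, with an expected range of 200 nM to 1000 nM.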

Compound 4, half-maximal inhibitory concentration: 180 nM
Estimate against measurement, compound 4: 2.5-fold (0.40 log units) above; the whole stated range lies above it.
By their numbers in this assay, from the lowest: compounds 4 and 3 (each within the scatter of the next); then compounds 2 and 1 (each within the scatter of the next).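

In this assay, hydroxy in place of 2-aminophenyl on an amide-type nitrogen gives a 1.3-fold lower number from compound 3 to compound 4 (0.12 log units; within the scatter), so on this chain the two end groups are not separated. With hydroxycarbamoyl held constant, the chain carries the difference: 3-(hydroxycarbamoyl)propyl gives a 3.4-fold lower number from compound 1 to compound 4 (0.53 log units; beyond the scatter) against the butyl chain and a 3.2-fold lower number from compound 2 to compound 4 (0.50 log units; beyond the scatter) against 4-(hydroxycarbamoyl)phenyl. No measurement at hand accounts for these steps. Open, as far as these compounds go, is whether a propyl chain with a carboxylic acid in place of hydroxycarbamoyl, or a still shorter chain, holds this level.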